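The compounds below may be only part of what the source reports. "The series", "measured", "known", "first", "only" and "open" are said of these compounds alone.

In a functional assay on A549 cells (Homo sapiens) for antiproliferative activity, read by MTT assay, with a stated time of 48 h (on this read-out higher numbers stand for weaker inhibition of growth and lower numbers for stronger inhibition of growth), compound 3 (`COc1ccc(/C=C2\Cc3cc(OC)c(OC)c(OC)c3C2=O)cc1[N+](=O)[O-]`) gives > 10000 nM, which is a limit of the assay and not a number. Compound 2 (`COc1ccc(/C=C2\Cc3cc(OC)c(OC)c(OC)c3C2=O)cc1O`) gives > 10000 nM, also a limit. Compound 1 (`COc1ccc(/C=C2\Cc3c(cc(OC)c(OC)c3OC)C2=O)cc1[N+](=O)[O-]`), on a core of its own, gives a true number, 770 nM.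

Compound 4 (`COc1ccc(/C=C2\Cc3cc(OC)c(OC)c(OC)c3C2=O)cc1`) keeps the core shared by compound 2 and compound 3 and has hydrogen in place of nitro on an aromatic carbon, ortho to a methoxy group: hydrogen in place of nitro on an aromatic carbon. Going by the values given here, the only measured step on this core is a step that the two limits leave unreadable from compound 2 to compound 3, so it offers no size to carry over. It shows only that neither the hydroxy nor the nitro compound gave a number.

Because of the limit of > 10000 nM in this assay, at which 2 of the 3 values shown sit, compound 4 is expected to stay near that limit as well, with no clear gain in growth inhibition. The estimated change is a step that the limit leaves unreadable from compound 3 to compound 4, and no step beyond the scatter is expected. For compound 4 the estimated value is 12000 nM, with an expected range from 4000 nM to 30000 nM.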

Compound 4, concentration for 50% growth inhibition: > 10000 nM
Compound 4 ended at the assay's limit; the forecaster's own chance of this, stated with the estimate: 80%; the middle value is on the limit's open side.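

No step among compound 2, compound 3 and compound 4 can be read, because each of their values is a limit and not a number: the limit of > 10000 nM in this assay, at which 3 of the 4 values shown sit.

The compounds shown leave open whether hydroxy, nitro and hydrogen on this shared core differ at all in this assay.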